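The compounds below may be only part of what the source reports. "The series", "measured", "known", "first", "only" and "open" are said of these compounds alone.

The series shares one core. Compound 1 `CC1=NN(c2ccc(C)cc2)C(=O)C12C=CC(=O)C=C2c1ccccc1` gives 46300 nM in a functional assay on A549 cells (Homo sapiens) for antiproliferative activity, read by CCK-8 assay, with a stated time of 72 h; a higher number here means a weaker inhibitor, a lower number a stronger inhibitor. Compound 2 `CC1=NN(c2ccc(Br)cc2)C(=O)C12C=CC(=O)C=C2c1ccccc1` reaches only the limit of this assay, > 100000 nM; that limit is the limit of > 100000 nM in this assay, at which 1 of the 3 values shown sits. Compound 3 `CC1=NN(c2cccc(Cl)c2)C(=O)C12C=CC(=O)C=C2c1cccc(C)c1`, which carries a 3-methylphenyl group on the core and a chloro group on the other aromatic ring, gives 20100 nM in this assay and so stands at the lowest of the two numbers, with compound 1 the nearest at a higher number.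

Compound 4 `CC1=NN(c2cccc(Cl)c2)C(=O)C12C=CC(=O)C=C2c1ccccc1` has not yet been measured. It differs from compound 3 by hydrogen in place of methyl on an aromatic carbon, so that the 3-methylphenyl becomes a phenyl. Within the data shown here, the only measured step, an at least 2.1-fold higher number from compound 1 to compound 2 (0.33 log units; beyond the scatter), changes the other aromatic ring and thus does not bear directly on this change. Among the measured compounds shown here, no measured step concerns the methyl on the 3-methylphenyl group. Compound 4 is therefore expected to give a number close to that of compound 3, with a step of a 1.5-fold higher number from compound 3 to compound 4 (0.17 log units; within the scatter) in this assay. Compound 4 is estimated at 30000 nM, with a range from 12000 nM to 80000 nM.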

Compound 4, half-maximal inhibitory concentration: 18800 nM
Compound 4: middle estimate off by 1.6-fold (0.20 log units), on the high side, within the range that was stated.
By their numbers in this assay, from the lowest: compounds 4 and 3 (each within the scatter of the next); then compound 1. At a limit, above all of these: compound 2.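

With the 3-chlorophenyl group on the amide-type nitrogen, the 3-methylphenyl and phenyl forms are not told apart in this assay: the methyl on an aromatic carbon can be replaced by hydrogen with a 1.1-fold lower number from compound 3 to compound 4 (0.03 log units; within the scatter) and no change beyond the scatter is seen at this position. With phenyl on the core, compound 4 also allows the group on the amide-type nitrogen to be compared, giving a 2.5-fold lower number from compound 1 to compound 4 (0.39 log units; beyond the scatter) and an at least 5.3-fold lower number from compound 2 to compound 4 (0.72 log units; beyond the scatter) as the two steps to 3-chlorophenyl. The second of these steps starts from a limit and not a number, that of compound 2: the limit of > 100000 nM in this assay, at which 1 of the 4 values shown sits.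

As far as these compounds go, only methyl and hydrogen are compared at this position, so a methoxy, a hydroxyl or an amine there remains open. Also open, from the compounds shown here alone, is whether a 3-methylphenyl on the core would leave the steps on the amide-type nitrogen unchanged.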